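A few compounds are considered here, and "the series" means these few. Any claim that something is new, unique, unknown or untested is made for them only; others in the source may bear on it.

Among the compounds with values here, compound 3 `Cc1ccc(NC(=O)C[C@H](CCC(=O)O)c2noc(-c3ccc(CC(C)C)cc3)c2C2CC2)c(Cl)c1` gives 80% in an ADME assay on microsomes from liver (Homo sapiens) for metabolic stability, with a stated time of 60 min (on this read-out lower numbers stand for a less stable compound and higher numbers for a more stable compound), the highest of the three numbers known here. Compound 2 `CNC(=O)CCC(CC(=O)Nc1ccc(C)cc1C)c1nnc(CCCC(C)C)n1C1CC1` gives 65% in this assay, and compound 1 `Cc1ccc(NC(=O)CC(CCO)c2nnc(CCCC(C)C)n2C2CC2)c(C)c1` gives 21%. Within the data shown here, the one change that has been followed step by step is a number 44 percentage points higher from compound 1 to compound 2 (beyond the scatter), a change on the saturated chain that these compounds share, not on the aromatic part.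

Compound 4 `Cc1ccc(NC(=O)C[C@H](CCC(=O)O)c2noc(-c3cc(C(F)(F)C(C)(C)C)on3)c2C2CC2)c(Cl)c1` is compound 3 with a different group on the five-membered ring: 5-(1,1-difluoro-2,2-dimethylpropyl)-1,2-oxazol-3-yl in place of 4-isobutylphenyl on an aromatic carbon. Among the measured compounds shown here, no measured step touches this part of the structure, so the single known step offers no guidance on the size or direction of the change in this assay, and the swap of one aromatic group for another cannot be judged from the chain data. In the absence of a comparable step, the expectation is that compound 4 stays close to compound 3, with an estimated step of a number 2 percentage points lower from compound 3 to compound 4 (within the scatter), none beyond the scatter. Compound 4 is therefore expected to give about 78% in this assay, within a range from 55% to 95%.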

Compound 4, percent of the compound remaining: 77%
Estimate against measurement, compound 4: 1 percentage points above; low and high end bracket the measured number.
By their numbers in this assay, from the lowest: compound 1; then compound 2; then compounds 4 and 3 (each within the scatter of the next).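

Placing 5-(1,1-difluoro-2,2-dimethylpropyl)-1,2-oxazol-3-yl instead of 4-isobutylphenyl on this aromatic carbon, next to the ring oxygen, gives in this assay a number 3 percentage points lower from compound 3 to compound 4 (within the scatter). The earlier compounds shown here showed a large step only on the saturated chain; this pair shows that a six-membered carbon ring can give way to a five-membered ring with 2 hetero atoms, plus two fluorine atoms, with no difference beyond the scatter at this position. Nothing here accounts for why the two groups read alike.

From the compounds shown here alone, the new ring and the fluorine-bearing side chain enter together, so what each contributes on its own remains open. Also open, going by these compounds, is whether a group carrying an amine or a longer unbranched carbon chain at this position would read the same.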